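The source may hold more compounds than are shown below. What is called first, only, known or untested is meant among the compounds shown, and "the series" means these compounds.

Working notes on the series. In a functional assay (Homo sapiens) (a lower number here means a stronger inhibitor, a higher number a weaker inhibitor), compound 1 `Nc1nc2ccnc(-c3cccc(C(F)(F)F)c3)n2n1` gives 2200 nM; 2200 nM (2 entries) and compound 2 `Nc1nc2ccnc(-c3cccc(OC(F)F)c3)n2n1` gives 3400 nM; 3400 nM (2 entries), so these two values sit within the usual scatter of each other. Compound 3 `Nc1nc2ccnc(-c3cccc(C(Cl)Cl)c3)n2n1` gives 1000 nM, a number below both of those, though this is its only numeric result and its two further entries carry no single number.

Compound 4 `CN(C)C(=O)c1cccc(-c2nccc3nc(N)nn23)c1` has dimethylcarbamoyl in place of dichloromethyl on an aromatic carbon. Within the data shown here, no measured pair isolates a change at this place, and no measured compound carries a dimethylcarbamoyl group. The expectation therefore rests only on the three values, with compound 3 at 1000 nM as the starting point. In this assay, a moderate move toward weaker inhibition is expected, with wide uncertainty. The expected change is a 4.5-fold higher number from compound 3 to compound 4 (0.65 log units; beyond the scatter). For compound 4, the estimated value is 4500 nM, with an expected range of 1300 nM to 16000 nM.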

Compound 4, half-maximal inhibitory concentration: 3500 nM
Estimate against measurement, compound 4: 1.3-fold (0.11 log units) above; low and high end bracket the measured number.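

In this assay, among these compounds, dimethylcarbamoyl in place of dichloromethyl gives a 3.5-fold higher number from compound 3 to compound 4 (0.54 log units; beyond the scatter), the first step that can be read at this place on the aromatic ring. The place therefore responds to the identity of the group, yet a group carrying a carbonyl and a hydrogen-bond acceptor still leaves a measurable inhibitor, with compound 4 at 3500 nM. Nothing available explains the step or separates the contribution of the carbonyl from that of the rest of the group.

Still open, as far as these compounds go, is whether a primary amide, a carboxylic acid or a simple amine at this place would stay close to compound 4 or move further from compound 3. With one step, no trend across groups at this place can yet be drawn.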